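Solubility of an oxazole-piperidine amide with a 2-methoxy-6-methylphenyl group

The source may hold more compounds than are shown below. What is called first, only, known or untested is meant among the compounds shown, and "the series" means these compounds.

The measured compounds in a physicochemical assay for solubility, in phosphate buffer, measured as kinetic solubility, at pH 7.4; a higher number here means a more soluble compound, a lower number a less soluble compound:
Compound 1 `Cc1oc(-c2ccc(Cl)cc2)nc1CN1CCC(C(=O)NCCCN2C[C@H](C)C[C@H](C)C2)CC1` gives > 72 ug/mL, which is a limit of the assay and not a number.
Compound 2 `Cc1ccccc1-c1nc(CN2CCC(C(=O)NCCCN3CCCC(CC(C)C)C3)CC2)c(C)o1` gives 54.9 ug/mL.
Compound 3 `Cc1ccccc1-c1nc(CN2CCC(C(=O)N3CCN(C4CCN(C)CC4)CC3)CC2)c(C)o1` gives > 71 ug/mL, again a limit of the assay rather than a number.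

Compound 1 therefore stands at the upper reach of what this assay reports, as the limit of > 72 ug/mL in this assay, at which 1 of the 3 values shown sits, shows, and compound 3 sits at a comparable limit, as the limit of > 71 ug/mL in this assay, at which 1 of the 3 values shown sits, shows. Among the compounds with values here, only compound 2 gives a plain number, and it carries a different amine, so no single-change step to any measured compound exists.

Compound 4 `COc1cccc(C)c1-c1nc(CN2CCC(C(=O)NCCCN3C[C@H](C)C[C@H](C)C3)CC2)c(C)o1` differs from compound 1 in one place: 2-methoxy-6-methylphenyl in place of 4-chlorophenyl on an aromatic carbon. Within the data shown here, no measured pair isolates this change, so the expected step is uncertain. Compound 1 is already at a limit, and compound 4 is expected to remain soluble, so the step of an at least 1.1-fold lower number from compound 1 to compound 4 (0.04 log units; that floor lies within the scatter) is expected to be small and not beyond the scatter. Compound 4 is estimated at 65 ug/mL, with a range from 30 ug/mL to 110 ug/mL, and quite possibly reported only as a limit again.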

Compound 4, solubility: > 73 ug/mL
Compound 4: a limit, no number (the forecaster's own chance of this, stated with the estimate: 55%); middle value at least 1.1-fold (0.05 log units) away from the limit.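

In this assay compound 4 gives > 73 ug/mL, a limit of the assay and not a number. Within the data shown here, compound 1 also gives a limit, > 72 ug/mL, so no step between compound 1 and compound 4 can be read. The compounds shown leave open what size of change, if any, 2-methoxy-6-methylphenyl in place of 4-chlorophenyl brings in this assay.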